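Swapping Chloro for Cyano on the Shared Core

The source may report more compounds than this note shows. Statements on the series, on what has been measured and on what is new or still open speak of the compounds shown alone.

Compound 3 `Clc1ccc(-c2cc3n(n2)CCCC3)nc1` gives 669 nM in a functional assay on HEK293 cells for negative allosteric modulation of metabotropic glutamate receptor 5 (Rattus norvegicus), read by FLIPR and calcium flux, with a stated time of 170 s (on this read-out higher numbers stand for weaker inhibition and lower numbers for stronger inhibition), the lowest of the three numbers in hand. Compound 1 `c1ccc(-c2cc3n(n2)CCCC3)nc1` gives 1290 nM and compound 2 `Cc1ccc(-c2cc3n(n2)CCCC3)nc1` gives 3000 nM in this assay. The step of a 1.9-fold lower number from compound 1 to compound 3 (0.29 log units; within the scatter) lies within the scatter, whereas the steps of a 4.5-fold lower number from compound 2 to compound 3 (0.65 log units; beyond the scatter) and a 2.3-fold higher number from compound 1 to compound 2 (0.37 log units; beyond the scatter) are modest and beyond it. Compound 4 `N#Cc1ccc(-c2cc3n(n2)CCCC3)nc1` carries cyano in place of chloro on an aromatic carbon, on an aromatic carbon of a six-membered aromatic ring with 1 nitrogen, two atoms from the ring nitrogen. Among the compounds with values here, no measured step exchanges chloro for cyano, so only the small spread across compounds 1, 2 and 3 bears on it. Compound 4 is therefore expected to show a step of a 1.3-fold lower number from compound 3 to compound 4 (0.13 log units; within the scatter) in this assay, not beyond the scatter. The estimate for compound 4 is 500 nM, ranging from 150 nM to 1600 nM.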

Compound 4, half-maximal inhibitory concentration: > 10000 nM
Compound 4: no number, only a limit; the forecaster's own chance of this, stated with the estimate: 5%; middle value at least 20-fold (1.30 log units) away from the limit.
By their numbers in this assay, from the lowest: compounds 3 and 1 (each within the scatter of the next); then compound 2. At a limit, above all of these: compound 4.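

In this assay compound 4 gives no number, only a limit: the limit of > 10000 nM in this assay, at which 1 of the 4 values shown sits. Hydrogen, methyl and chloro at this position had stayed close together, but cyano brings a far larger change than any of them, with an at least 14-fold higher number from compound 3 to compound 4 (1.17 log units; beyond the scatter), an at least 7.7-fold higher number from compound 1 to compound 4 (0.88 log units; beyond the scatter) and an at least 3.3-fold higher number from compound 2 to compound 4 (0.52 log units; beyond the scatter). The position therefore does not accept every replacement of chloro, even one as small as this nitrile.

Going by these compounds, how far compound 4 lies past its limit stays open, and so does the true size of these steps. The compounds shown also leave open whether fluoro, methoxy or an amine at this position would behave like chloro or like cyano.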